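This account rests on a few compounds, and the source may have more. Where it says the series, first, only, none or still open, it means among the compounds named here.

In a functional assay on U-251 cells (Homo sapiens) for inhibition, read by sulforhodamine B assay, with a stated time of 48 h, tested at 10 uM (on this read-out higher numbers stand for more inhibition at the one concentration tested (going by the name of the read-out) and lower numbers for less inhibition), the three measured compounds give the following:

compound 1, `COc1ccc(-c2cn3ccnc3c(-c3ccc4ncn(C5CCCCC5)c4c3)n2)cc1`: 80.9%
compound 2, `O=Cc1ccc(-c2cn3ccnc3c(-c3ccc4ncn(C5CCCCC5)c4c3)n2)cc1`: 32%
compound 3, `c1cn2cc(-c3ccsc3)nc(-c3ccc4ncn(C5CCCCC5)c4c3)c2n1`: 6.09%

Compound 2 stands second highest of these three numbers. Its nearest neighbour is compound 3, the distance being a number 25.9 percentage points lower from compound 2 to compound 3 (beyond the scatter), and the furthest is compound 1, the distance being a number 48.9 percentage points lower from compound 1 to compound 2 (beyond the scatter).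

Compound 4, `COc1ccccc1-c1cn2ccnc2c(-c2ccc3ncn(C4CCCCC4)c3c2)n1`, is not yet measured. It differs from compound 2 in one place: 2-methoxyphenyl in place of 4-formylphenyl on an aromatic carbon. For the measured compounds named here, one measured step bears directly on this change, a number 48.9 percentage points lower from compound 1 to compound 2 (beyond the scatter), which exchanged the same two groups in the opposite direction and was large. Going by the values given here, compound 4 brings the methoxy back, but as 2-methoxyphenyl rather than the 4-methoxyphenyl of compound 1, and no measured compound carries that group, so the recovery is uncertain in size. A clear rise in this assay is therefore expected, though not necessarily the whole of the earlier fall. Compound 4 is estimated at 60%, within 30% to 85%, an expected step of a number 28 percentage points higher from compound 2 to compound 4 (beyond the scatter).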

Compound 4, a percentage reported as inhibition, at one concentration (the size of the read-out at that concentration, not a potency): 21%
The estimate for compound 4 lay 39 percentage points above the measured number, outside the stated range (below it).
By their numbers in this assay, from the lowest: compound 3; then compound 4; then compound 2; then compound 1.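

The methoxy group alone does not carry the high number of compound 1 in this assay: with 2-methoxyphenyl in place of 4-methoxyphenyl on this aromatic carbon, the result is a number 59.9 percentage points lower from compound 1 to compound 4 (beyond the scatter) and a large loss. Among the four groups shown, only 4-methoxyphenyl reaches the high end. The 2-methoxyphenyl group also gives no gain over 4-formylphenyl, with a number 11 percentage points lower from compound 2 to compound 4 (beyond the scatter) as a modest step, and stands only modestly over thiophen-3-yl, with a number 14.9 percentage points higher from compound 3 to compound 4 (beyond the scatter) as the step. No measurement here accounts for these differences.

On these data alone, whether a phenyl ring carrying an amine or a hydroxyl group in place of the methoxy would hold the number of compound 1 remains open. So does whether a longer ether such as ethoxy would.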